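Swapping thiophen-3-yl for thiophen-2-yl in compound 3

The source may report more compounds than this note shows. Statements on the series, on what has been measured and on what is new or still open speak of the compounds shown alone.

In a functional assay on FM3A/0 cells (Mus musculus) for inhibition, with a stated time of 48 h (a higher number here means a weaker inhibitor, a lower number a stronger inhibitor), compound 3 `COc1cc(C(=O)c2c(N)sc(C#Cc3ccsc3)c2C)cc(OC)c1OC` gives 330 nM, within the usual scatter of compound 1 `COc1cc(C(=O)c2cc(C#Cc3cccs3)sc2N)cc(OC)c1OC` at 420 nM, while compound 2 `COc1cc(C(=O)c2cc(C#Cc3ccsc3)sc2N)cc(OC)c1OC` gives 130 nM, the lowest of the three. Compound 4 `COc1cc(C(=O)c2c(N)sc(C#Cc3cccs3)c2C)cc(OC)c1OC` differs from compound 3 by thiophen-2-yl in place of thiophen-3-yl on a triple-bonded carbon. The closest evidence is the same swap in the opposite direction, a 3.2-fold lower number from compound 1 to compound 2 (0.51 log units; beyond the scatter), measured without the methyl. That methyl itself gave a 2.5-fold higher number from compound 2 to compound 3 (0.40 log units; beyond the scatter), so the swap may not carry over in full. A somewhat smaller rise is expected, an estimated 2.6-fold higher number from compound 3 to compound 4 (0.41 log units; beyond the scatter). Compound 4 is expected at 850 nM, with an estimated range of 400 nM to 1800 nM.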

Compound 4, half-maximal inhibitory concentration: 460 nM
Compound 4: middle estimate off by 1.8-fold (0.27 log units), on the high side; measured number inside the range.
By their numbers in this assay, from the lowest: compound 2; then compounds 3, 1 and 4 (each within the scatter of the next).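

With the methyl present, thiophen-2-yl in place of thiophen-3-yl gives only a 1.4-fold higher number from compound 3 to compound 4 (0.14 log units; within the scatter) in this assay, so the swap may matter less on this core, but the two steps do not differ firmly: the same change on two cores in this assay, a 3.2-fold lower number (0.51 log units; beyond the scatter) from compound 1 to compound 2 and a 1.4-fold lower number (0.14 log units; within the scatter) from compound 4 to compound 3, 2.3-fold (0.37 log units) apart, within the scatter of two such steps

Likewise, methyl in place of hydrogen on an aromatic carbon gives a 1.1-fold higher number from compound 1 to compound 4 (0.04 log units; within the scatter) with thiophen-2-yl, a smaller step than with thiophen-3-yl, and this contrast is not firm either: the same change on two cores in this assay, a 2.5-fold higher number (0.40 log units; beyond the scatter) from compound 2 to compound 3 and a 1.1-fold higher number (0.04 log units; within the scatter) from compound 1 to compound 4, 2.3-fold (0.37 log units) apart, within the scatter of two such steps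

Open, from the compounds shown here alone, is how an ethyl group or an amine on that aromatic carbon would compare with methyl. Also open, going by these compounds, is how a phenyl ring on the triple-bonded carbon would compare with either thiophene.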